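Notes: 2-chlorobenzyl in place of phenyl on compound 3

The source may hold more compounds than are shown below. What is called first, only, known or untested is meant among the compounds shown, and "the series" means these compounds.

Values in a functional assay on PC-3 cells (Homo sapiens) for antiproliferative activity, read by MTT assay, with a stated time of 48 h (on this read-out higher numbers stand for weaker inhibition and lower numbers for stronger inhibition), for the measured compounds:
compound 1 `Clc1cnc(Nc2cn[nH]c2)nc1Nc1ccccc1` gives 5380 nM
compound 2 `Clc1ccccc1Nc1nc(Nc2cn[nH]c2)ncc1Cl` gives 1130 nM
compound 3 `c1ccc(Nc2nc(Nc3cn[nH]c3)nc3[nH]ccc23)cc1` gives 4470 nM

Compound 3 lies within the scatter of compound 1. Compound 2 has the lowest number of the three, and its gap to compound 3 is beyond the scatter.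

Compound 4 `Clc1ccccc1CNc1nc(Nc2cn[nH]c2)nc2[nH]ccc12` is still to be measured. Against compound 3 it carries 2-chlorobenzyl in place of phenyl on a nitrogen on an aromatic ring.

For the measured compounds named here, one measured step bears on this change: a 4.8-fold lower number from compound 1 to compound 2 (0.68 log units; beyond the scatter), a modest step for chloro in place of hydrogen on an aromatic carbon. That step was seen on the core of compound 1 and not on the core of compound 3. Going by the values given here, no measured pair shows what a benzyl in place of a phenyl does here, so the transfer is uncertain.

A step of similar or smaller size toward a lower number is therefore expected in this assay, and a result within the scatter of compound 3 remains possible. The expected step is a 3.0-fold lower number from compound 3 to compound 4 (0.47 log units; beyond the scatter). The estimate for compound 4 is 1500 nM, with an expected range from 400 nM to 5000 nM.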

Compound 4, half-maximal inhibitory concentration: 13500 nM
Compound 4: the middle estimate sits 9.0-fold (0.95 log units) below what was measured; the measured number lies above the stated range.
By their numbers in this assay, from the lowest: compound 2; then compounds 3 and 1 (each within the scatter of the next); then compound 4.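

In this assay the change to 2-chlorobenzyl in place of phenyl on a nitrogen on an aromatic ring gives a 3.0-fold higher number from compound 3 to compound 4 (0.48 log units; beyond the scatter) and moves the series toward weaker inhibition, so this position on the core of compound 3 responds to the group it carries. The earlier step of a 4.8-fold lower number from compound 1 to compound 2 (0.68 log units; beyond the scatter) ran toward a lower number on the core of compound 1, so a chloro-bearing ring on that nitrogen does not go with stronger inhibition in both cores, although the two changes are not the same change and sit on different cores. Nothing at hand accounts for the rise from phenyl to 2-chlorobenzyl.

The compounds shown leave open whether the rise goes with the extra carbon link or with the chloro; a plain benzyl and a chloro-bearing phenyl, each on the core of compound 3, would separate the two. Also open, on these data alone, is how this position responds to groups of another kind in place of the ring, such as a longer chain ending in an amine or a carboxylic acid.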